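Free fraction on swapping the ring at the carbonyl carbon

The source may report more compounds than this note shows. Statements on the series, on what has been measured and on what is new or still open speak of the compounds shown alone.

Of the compounds shown here, two have been measured in an ADME assay for protein binding, using equilibrium dialysis, at pH 7.4, tested at 2 uM; on this read-out higher numbers stand for a larger free fraction and lower numbers for a smaller free fraction. Compound 1 `CC1CC=C(C(=O)N(c2cc(C#CC(C)(C)C)sc2C(=O)O)C(C)C)CC1` gives 0.08 in this assay, and compound 2 `CC(C)N(C(=O)C1CCCCCC1)c1cc(C#CC(C)(C)C)sc1C(=O)O` gives 0.11, the highest of the two numbers, with the step of a 1.4-fold higher number from compound 1 to compound 2 (0.14 log units; within the scatter) lying within the scatter. Compound 3 `CC(C)N(C(=O)C1CCC(F)(F)CC1)c1cc(C#CC(C)(C)C)sc1C(=O)O` has not yet been measured. It differs from compound 2 in one place: 4,4-difluorocyclohexyl in place of cycloheptyl on a carbonyl carbon. Going by the values given here, the only step recorded, that from compound 1 to compound 2, also exchanged the ring on that carbonyl carbon and was small, so no bearing beyond this can be drawn from the data. Compound 3 is therefore expected to show a step of a 1.3-fold higher number from compound 2 to compound 3 (0.10 log units; within the scatter), not beyond the scatter. The estimate for compound 3 in this assay is 0.14, expected to lie between 0.07 and 0.28.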

Compound 3, unbound fraction: 0.4
Compound 3: middle estimate off by 2.9-fold (0.46 log units), on the low side; the whole stated range lies below it.
By their numbers in this assay, from the lowest: compounds 1 and 2 (each within the scatter of the next); then compound 3.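

Unlike the earlier ring exchange, this one shows that the ring on the carbonyl carbon can move the free fraction in this assay beyond the scatter. Placing 4,4-difluorocyclohexyl there in place of cycloheptyl gives a 3.6-fold higher number from compound 2 to compound 3 (0.56 log units; beyond the scatter), and placing it there in place of 4-methylcyclohex-1-en-1-yl gives a 5.0-fold higher number from compound 1 to compound 3 (0.70 log units; beyond the scatter). No measurement offered here accounts for this rise.

Compound 3 differs from compound 2 both in ring size and in carrying fluorine, and the compounds shown do not separate these two changes. A plain cyclohexyl on the same carbonyl carbon would address that question, while a tetrahydropyranyl ring there would test whether an atom other than fluorine gives a similar result.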